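Extending the Amine Side Chain of a Cyclopropyl Ketone

A few compounds are considered here, and "the series" means these few. Any claim that something is new, unique, unknown or untested is made for them only; others in the source may bear on it.

Compound 1 `O=C(c1ccc(NCc2ccco2)cc1)C1CC1c1ccc(Cl)cc1` was examined in an ADME assay on Vero cells (Chlorocebus sabaeus) for cytotoxicity, with a stated time of 72 h (on this read-out higher numbers stand for lower toxicity in this test and lower numbers for higher toxicity in this test), where compound 1 gives 256 ug/mL. Among the two numbers gathered so far this is the lowest, though its nearest companion sits within the scatter: compound 2 `O=C(c1ccc(N2CCCC2)cc1)C1CC1c1ccc(Cl)cc1`, which in this assay gives 431 ug/mL, is separated from it by a 1.7-fold higher number from compound 1 to compound 2 (0.23 log units; within the scatter), a change that puts pyrrolidin-1-yl in place of ((furan-2-yl)methyl)amino on an aromatic carbon. Compound 3 `O=C(c1ccc(NCCn2cnc3ccccc32)cc1)C1CC1c1ccc(Cl)cc1` has not yet been tested. It differs from compound 1 as follows: (1H-benzimidazol-1-yl)methyl in place of furan-2-yl on a saturated chain carbon bound to a nitrogen on an aromatic ring. Among the measured compounds shown here, no measured step touches this part of the molecule; the single step in hand replaces the whole substituent on the aromatic nitrogen and stays within the scatter, so it gives only a weak guide. The account therefore expects compound 3 to stay near compound 1, with at most a modest move toward lower numbers, and the expected step is a 1.3-fold lower number from compound 1 to compound 3 (0.13 log units; within the scatter). In this assay, compound 3 is estimated to give about 190 ug/mL, within a range from 70 ug/mL to 500 ug/mL.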

Compound 3, half-maximal cytotoxic concentration: 285 ug/mL
The estimate for compound 3 lay 1.5-fold (0.18 log units) below the measured number; low and high end bracket the measured number.
By their numbers in this assay, from the lowest: compounds 1, 3 and 2 (each within the scatter of the next).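

In this assay, the change on the saturated chain carbon bound to a nitrogen on an aromatic ring gives a 1.1-fold higher number from compound 1 to compound 3 (0.05 log units; within the scatter), even though the entering (1H-benzimidazol-1-yl)methyl has 10 heavy atoms against the 5 of furan-2-yl and adds a six-membered aromatic ring of carbon only. Among the compounds shown here, the earlier step replaced the whole substituent on the aromatic carbon, whereas this one leaves the nitrogen in place and alters only what the chain carries, so it is the first reading of this position alone: here, a larger group with one more hydrogen-bond acceptor leaves the number within the scatter. No evidence is available that would explain this outcome.

The compounds shown leave open whether any group at this place can move the number beyond the scatter, for example a carboxylic acid, a dimethylamino group or a morpholine ring. As far as these compounds go, it also remains open whether a longer chain ending in 1H-benzimidazol-1-yl would stay as close to compound 1 in this assay.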